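Octyl versus decyl chain on the triazole in two amine series

The compounds below may be only part of what the source reports. "The series", "measured", "known", "first", "only" and "open" are said of these compounds alone.

Compound 1 `CCCCCCCCn1cc(/C=C/C(=O)c2ccc(NC(=O)CN3CCN(c4ccccc4)CC3)cc2)nn1` and compound 2 `CCCCCCCCCCn1cc(/C=C/C(=O)c2ccc(NC(=O)CN3CCN(c4ccccc4)CC3)cc2)nn1` share one core and differ only in the chain on the aromatic nitrogen. In a functional assay on MCF7 cells (Homo sapiens) for inhibition, read by MTT assay (on this read-out lower numbers stand for stronger inhibition and higher numbers for weaker inhibition), compound 1 gives 31900 nM. Compound 2 reaches only the limit of this assay, > 100000 nM; this is a limit and not a number (the limit of > 100000 nM in this assay, at which 1 of the 3 values shown sits). The step between them, (hydrogen in place of ethyl on a saturated chain carbon, eight bonds along the chain from an aromatic nitrogen), reads an at least 3.1-fold lower number from compound 2 to compound 1 (0.49 log units; beyond the scatter).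

Compound 3 `CCCCCCCCCCn1cc(/C=C/C(=O)c2ccc(NC(=O)CN3CCC(Cc4ccccc4)CC3)cc2)nn1` carries the longer chain on a different core; the difference between the two cores is not broken down here. In this assay compound 3 gives 55200 nM.

Compound 4 `CCCCCCCCn1cc(/C=C/C(=O)c2ccc(NC(=O)CN3CCC(Cc4ccccc4)CC3)cc2)nn1` is not yet measured. Among the measured compounds shown here, it differs from compound 3 by hydrogen in place of ethyl on a saturated chain carbon, eight bonds along the chain from an aromatic nitrogen, the same change as the one from compound 2 to compound 1, at the same place. The expectation for compound 4 rests on the step of an at least 3.1-fold lower number from compound 2 to compound 1 (0.49 log units; beyond the scatter), which is only a lower bound for the shortening because compound 2 sits at the limit (the limit of > 100000 nM in this assay, at which 1 of the 3 values shown sits). Compound 4 is therefore expected to move by about a 3.1-fold lower number from compound 3 to compound 4 (0.49 log units; beyond the scatter), which is roughly the size seen once already.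

The estimate for compound 4 in this assay is 18000 nM, expected to fall between 6000 nM and 50000 nM.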

Compound 4, half-maximal inhibitory concentration: 52600 nM
The estimate for compound 4 lay 2.9-fold (0.47 log units) below the measured number; measured number outside the range, above it.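

On the core of compound 3, the replacement of ethyl by hydrogen reads a 1.0-fold lower number from compound 3 to compound 4 (0.02 log units; within the scatter) in this assay, so the shortening from decyl to octyl does not carry over from the core of compound 1 at the size seen there: the same change on two cores in this assay, an at least 3.1-fold lower number (0.49 log units; beyond the scatter) from compound 2 to compound 1 and a 1.0-fold lower number (0.02 log units; within the scatter) from compound 3 to compound 4, at least 2.9-fold (0.47 log units) apart, beyond the scatter of two such steps

The step on the core of compound 1 is only a lower bound, since the value of compound 2 is a limit and not a number: the limit of > 100000 nM in this assay, at which 1 of the 4 values shown sits.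

These two pairs show that the outcome of this change depends on the core in this assay, but they do not show what in the two cores produces the gap, and they set no rule for other cores in the series.

Still open, going by these compounds, is whether a hexyl or a dodecyl chain on the aromatic nitrogen would follow the pattern of the core of compound 1 or that of the core of compound 3. On these data alone, the true size of the step on the core of compound 1 also remains open, as compound 2 has no number.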